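The source may hold more compounds than are shown below. What is called first, only, known or untested is meant among the compounds shown, and "the series" means these compounds.

Two nucleoside analogues share a sugar attached to a fused two-ring core, and both have been tested in a functional assay on A549 cells (Homo sapiens), read by MTT assay, with a stated time of 72 h; on this read-out higher numbers stand for weaker inhibition and lower numbers for stronger inhibition. Compound 1 `Nc1nc(N)c2c(-c3ccsc3)cn([C@@H]3O[C@H](CO)[C@@H](O)[C@H]3O)c2n1` carries a thiophen-3-yl group on its core, with two amino groups on the six-membered ring. In this assay compound 1 gives only a limit of the assay, > 100000 nM, and no number. Compound 2 `COc1ncnc2c1c(I)cn2[C@@H]1O[C@H](CO)[C@@H](O)[C@H]1O` carries a methoxy group on the six-membered ring and an iodo on the five-membered ring. In this assay compound 2 also gives only a limit of the assay, > 20000 nM, so its true inhibition is not known beyond that mark. Both values sit at limits, shown by the limit of > 100000 nM in this assay, at which 1 of the 2 values shown sits, and (the limit of > 20000 nM in this assay, at which 1 of the 2 values shown sits), so no step between measured compounds can be sized.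

Compound 3 `COc1ncnc2c1c(-c1cc3ccccc3o1)cn2[C@@H]1O[C@H](CO)[C@@H](O)[C@H]1O` differs from compound 2 in one place: 1-benzofuran-2-yl in place of iodo on an aromatic carbon. For the measured compounds named here, no measured pair here tells how such a change moves this read-out, so the expectation rests on the change alone. The step from compound 2 to compound 3 is expected to be an at least 4.0-fold lower number from compound 2 to compound 3 (0.60 log units; beyond the scatter), toward stronger inhibition. Compound 3 is estimated at 5000 nM, within a range from 500 nM to 30000 nM.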

Compound 3, half-maximal inhibitory concentration: 17700 nM
Beside the measured number, compound 3's estimate is 3.5-fold (0.55 log units) below it; measured number inside the range.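

In this assay, for the compounds shown here, compound 3 is the first compound here to give a number rather than a limit, 17700 nM, so this aromatic carbon of the five-membered ring can carry 1-benzofuran-2-yl, with its 9 heavy atoms and two aromatic rings, and inhibition can still be read as a value. Replacing iodo with this group gives an at least 1.1-fold lower number from compound 2 to compound 3 (0.05 log units; that floor lies within the scatter), which means the data cannot yet show that the change improves inhibition, although the true step could be larger than this floor. The step can be given only as a floor because compound 2 stands at a limit of the assay: the limit of > 20000 nM in this assay, at which 1 of the 3 values shown sits.

Going by these compounds, it remains open how a smaller ring such as phenyl, an amine or a carboxylic acid on the same aromatic carbon would move the read-out, and so whether ring size or the ring oxygen has any bearing on it. The methoxy group on the six-membered ring also remains untested as a separate change, as no pair shown pairs it with the two amino groups of compound 1 while keeping all else the same.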